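Dicinnamylidene-type ketones: methoxy to fluoro on one aryl ring

The source may report more compounds than this note shows. Statements on the series, on what has been measured and on what is new or still open speak of the compounds shown alone.

Compound 1 `COc1ccc(/C=C2\CCC/C(=C\c3ccc([N+](=O)[O-])cc3)C2=O)cc1` gives 300000 nM in a functional assay on MOLT-4 cells (Homo sapiens) for cytotoxicity, with a stated time of 72 h (a lower number here means a stronger inhibitor, a higher number a weaker inhibitor), the highest number among the two compounds measured. Compound 2 `Cc1ccc(/C=C2\CCC/C(=C\c3cccc([N+](=O)[O-])c3)C2=O)cc1` gives 9530 nM in this assay; the two differ in more than one place, so the gap itself is not traced to a single change. Compound 3 `O=C1/C(=C/c2ccc(F)cc2)CCC/C1=C\c1ccc([N+](=O)[O-])cc1` differs from compound 1 in one place: fluoro in place of methoxy on an aromatic carbon. Within the data shown here, no single-change step between measured compounds exists to calibrate this, so a modest step toward a lower number is expected for a 2.0-fold lower number from compound 1 to compound 3 (0.30 log units; within the scatter), not far beyond the scatter. Compound 3 is estimated at 150000 nM, within 30000 nM to 500000 nM.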

Compound 3, half-maximal inhibitory concentration: 17100 nM
Beside the measured number, compound 3's estimate is 8.8-fold (0.94 log units) above it, outside the stated range (below it).
By their numbers in this assay, from the lowest: compounds 2 and 3 (each within the scatter of the next); then compound 1.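

Fluoro in place of methoxy on an aromatic carbon, para to a large group, gives the first single-place step in the series: in this assay it is an 18-fold lower number from compound 1 to compound 3 (1.24 log units; beyond the scatter) and lies beyond the scatter. The position on this ring is therefore not silent, since 4-methoxyphenyl to 4-fluorophenyl alone moves the number by that much. Nothing available accounts for the size of this step.

Open, going by these compounds, is whether chloro, hydroxyl or a dimethylamino group here would give a number nearer that of fluoro or of methoxy. Among these compounds, also open is whether the same change carries over with a different second aryl ring, such as the one in compound 2.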